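Swapping the aryl group on the thiourea of a thiophene amide

A few compounds are considered here, and "the series" means these few. Any claim that something is new, unique, unknown or untested is made for them only; others in the source may bear on it.

Compound 1 `NC(=O)c1c(NC(=O)c2ccccc2Cl)sc2c1CCN(C(=S)Nc1ccccc1Br)C2`: 10800 nM
Compound 2 `COc1ccccc1NC(=S)N1CCc2c(sc(NC(=O)c3ccccc3Cl)c2C(N)=O)C1`: 35200 nM
Compound 3 `NC(=O)c1c(NC(=O)c2ccccc2Cl)sc2c1CCN(C(=S)Nc1ccccc1-c1ccccc1)C2`: 25800 nM

In a functional assay on MKN-74 cells (Homo sapiens) for antiproliferative activity, with a stated time of 24 h (on this read-out higher numbers stand for weaker inhibition and lower numbers for stronger inhibition), compound 3 stands second highest of the three numbers, close to compound 2 and a modest step away from compound 1. Compound 4 `NC(=O)c1c(NC(=O)c2ccccc2Cl)sc2c1CCN(C(=S)Nc1ccc(C(F)(F)F)cc1)C2` differs from compound 3 by 4-(trifluoromethyl)phenyl in place of 2-phenylphenyl on an amide-type nitrogen. Among the measured compounds shown here, the steps that bear on this change all vary the group on that nitrogen: a 3.3-fold higher number from compound 1 to compound 2 (0.51 log units; beyond the scatter) and a 2.4-fold higher number from compound 1 to compound 3 (0.38 log units; beyond the scatter) were modest, while a 1.4-fold lower number from compound 2 to compound 3 (0.13 log units; within the scatter) stayed within the scatter. Such changes have therefore shifted this assay only modestly, and none of them tested a trifluoromethyl group, so the direction is uncertain. Compound 4 is expected to give 20000 nM, within 8000 nM to 50000 nM, meaning an expected step of a 1.3-fold lower number from compound 3 to compound 4 (0.11 log units; within the scatter).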

Compound 4, half-maximal inhibitory concentration: 7090 nM
For compound 4 the middle estimate is 2.8-fold (0.45 log units) above the measured one; the whole stated range lies above it.
By their numbers in this assay, from the lowest: compounds 4 and 1 (each within the scatter of the next); then compounds 3 and 2 (each within the scatter of the next).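

In this assay, 4-(trifluoromethyl)phenyl on this amide-type nitrogen gives a 3.6-fold lower number from compound 3 to compound 4 (0.56 log units; beyond the scatter) when it replaces 2-phenylphenyl, and a 5.0-fold lower number from compound 2 to compound 4 (0.70 log units; beyond the scatter) when it replaces 2-methoxyphenyl. Replacing 2-bromophenyl gives only a 1.5-fold lower number from compound 1 to compound 4 (0.18 log units; within the scatter), so the new group matches the level of the bromo compound but does not go past it. Nothing available explains these differences. From the compounds shown here alone, it remains open how this assay would respond to an unsubstituted phenyl group on this nitrogen, or to a phenyl ring carrying an amine or a carboxylic acid.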